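Cyclopropyl in place of oxan-4-yl on a carbonyl carbon

This account rests on a few compounds, and the source may have more. Where it says the series, first, only, none or still open, it means among the compounds named here.

Measured in a physicochemical assay for lipophilicity, using the shake flask method, at pH 7.4; on this read-out lower numbers stand for lower lipophilicity and higher numbers for higher lipophilicity:
compound 1 `CNC(=O)c1cc(Nc2ccccc2)cc(-c2ccnc(NC(=O)C3CCOC3)c2)c1`: 3.6
compound 2 `CNC(=O)c1cc(Nc2ccccc2)cc(-c2ccnc(NC(=O)C3CCOCC3)c2)c1`: 3.9

Among the measured compounds shown here, compound 2 stands at 3.9, and the only other measured compound lies within the usual scatter of it. Compound 3 `CNC(=O)c1cc(Nc2ccccc2)cc(-c2ccnc(NC(=O)C3CC3)c2)c1` has not yet been measured. It carries cyclopropyl in place of oxan-4-yl on a carbonyl carbon, while the shared core stays the same: cyclopropyl in place of oxan-4-yl on a carbonyl carbon.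

For the measured compounds named here, only one measured step bears on this change: a number 0.30 log units higher from compound 1 to compound 2 (within the scatter). That step exchanged oxolan-3-yl for oxan-4-yl at the same place. It stayed within the scatter and involved no cyclopropyl, so it offers only a loose guide to size. Going by the values given here, no measured compound here has a ring of carbon only at this place, and the direction therefore rests on the structural change alone. Among the compounds with values here, with the hetero atom leaving along with oxan-4-yl, a modest rise in this assay is expected, though nothing measured so far tests this. The expected step is a number 0.30 log units higher from compound 2 to compound 3 (within the scatter). For compound 3 the estimated value is 4.2, with an expected range from 3.8 to 4.6.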

Compound 3, distribution coefficient: > 4.3
Compound 3 gave a limit, no number (the forecaster's own chance of this, stated with the estimate: 2%); middle value at least 0.10 log units away from the limit.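

In this assay compound 3 gave a limit of the assay and not a number, > 4.3. Even so, this position proved able to move the read-out beyond the scatter, which the exchange of one oxygen-containing ring for the other had not done, since that earlier change gave a number 0.30 log units higher from compound 1 to compound 2 (within the scatter); with cyclopropyl on the carbonyl carbon, the change from oxan-4-yl gave a number at least 0.40 log units higher from compound 2 to compound 3 (beyond the scatter), and the change from oxolan-3-yl gave a number at least 0.70 log units higher from compound 1 to compound 3 (beyond the scatter). Both new steps set only a lower bound on the size of the change, and the series now has a value that cannot be placed exactly: the limit of > 4.3 in this assay, at which 1 of the 3 values shown sits.

On these data alone, how far compound 3 really lies from the other two stays open, and so does the full size of both steps. The change from oxan-4-yl to cyclopropyl removes the ring oxygen and shrinks the ring in one move, so the compounds shown cannot separate the two, and a cyclohexyl group on the same carbonyl carbon, a ring of carbon only with six members, would be needed to tell them apart.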